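Adding One Chloro to Compound 3

A few compounds are considered here, and "the series" means these few. Any claim that something is new, unique, unknown or untested is made for them only; others in the source may bear on it.

In a functional assay on RS4-11 cells (Homo sapiens) for inhibition, read by CCK-8 assay, with a stated time of 48 h, tested at 20 uM (a lower number here means less inhibition of growth, a higher number more inhibition of growth at the concentration tested), compound 1 `COc1ccc(S(=O)(=O)Oc2ccccc2/C=C(\C#N)C(=O)Nc2nnc(-c3cccs3)s2)cc1` gives 76% and compound 2 `N#C/C(=C\c1ccccc1OS(=O)(=O)c1ccc([N+](=O)[O-])cc1)C(=O)Nc1nnc(-c2cccs2)s1` gives 40%. Compound 3 `Cc1ccc(S(=O)(=O)Oc2cccc(/C=C(\C#N)C(=O)Nc3nnc(-c4ccccc4)s3)c2)cc1` gives 35%, which is level with compound 2 within the usual scatter and well under compound 1.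

Compound 4 `Cc1ccc(S(=O)(=O)Oc2cccc(/C=C(\C#N)C(=O)Nc3nnc(-c4ccccc4Cl)s3)c2)cc1` is compound 3 with a single change: chloro in place of hydrogen on an aromatic carbon. In words, this is chloro in place of hydrogen on an aromatic carbon, turning phenyl into 2-chlorophenyl.

Going by the values given here, only one measured step bears on this, and only loosely: a number 36 percentage points lower from compound 1 to compound 2 (beyond the scatter), a large step with nitro in place of methoxy on an aromatic carbon. It shows that one swapped group can shift growth inhibition strongly in this small set. However, it involves different groups, and no measured pair shows what a chloro does. A modest rise in this assay is therefore expected, possibly none beyond the scatter. The estimated step is a number 5 percentage points higher from compound 3 to compound 4 (within the scatter). For compound 4 the estimate is 40%, with an expected range from 22% to 62%.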

Compound 4, percent growth inhibition at one concentration: 44%
Compound 4: the middle estimate sits 4 percentage points below what was measured, and the stated range covers the measured number.
By their numbers in this assay, from the lowest: compounds 3, 2 and 4 (each within the scatter of the next); then compound 1.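

Going by these compounds alone, this pair is the first in the set to isolate what a chloro does. In this assay, turning phenyl into 2-chlorophenyl, on an aromatic carbon ortho to a large group, gives a number 9 percentage points higher from compound 3 to compound 4 (within the scatter). So this carbon of the ring accepts a chloro, and the growth inhibition stays level with that of the unsubstituted phenyl within the usual scatter of repeated measurements; nothing shown here offers an explanation for this result.

The compounds shown leave open whether an amine or a carboxylic acid on this same carbon would shift growth inhibition beyond the scatter. They also leave open whether a chloro on another carbon of this ring would behave as it does here, and a reading at a single concentration cannot show how the two compounds would compare at other concentrations.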